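Moving the Fluorine on the Urea Aryl Group

The compounds below may be only part of what the source reports. "The series", "measured", "known", "first", "only" and "open" are said of these compounds alone.

Of the compounds shown here, two have been measured in a functional assay on cells (Neutrophil, Homo sapiens) for inhibition, with a stated time of 10 min; on this read-out higher numbers stand for weaker inhibition and lower numbers for stronger inhibition. Compound 1 `O=C(Nc1ccc(F)cc1)N1c2ccnn2CC1c1ccccc1` gives 95 nM, while compound 2 `NC(=O)c1cnn2c1N(C(=O)Nc1cccc(F)c1)C(c1ccccc1)C2` gives 3.9 nM, the lower of the two numbers and a gap that lies beyond the usual scatter. Compounds 1 and 2 differ in more than one place, so no single step between them is shown; their two values are all that can be said of the pair. Compound 3 `NC(=O)c1cnn2c1N(C(=O)Nc1ccc(F)cc1)C(c1ccccc1)C2` has not yet been measured. It is built from compound 2 by one change: 4-fluorophenyl in place of 3-fluorophenyl on an amide-type nitrogen. Compound 1 also carries a 4-fluorophenyl group on that nitrogen, yet it lacks the carboxamide of compound 2, so its value cannot be set against compound 2 alone. In this assay the step from compound 2 to compound 3 is expected to be small, a 1.5-fold higher number from compound 2 to compound 3 (0.19 log units; within the scatter), either slightly toward a higher number or none beyond the scatter. Compound 3 is therefore estimated at 6 nM, within 2 nM to 25 nM.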

Compound 3, half-maximal inhibitory concentration: 11.4 nM
Compound 3: the middle estimate sits 1.9-fold (0.28 log units) below what was measured, and the stated range covers the measured number.
By their numbers in this assay, from the lowest: compound 2; then compound 3; then compound 1.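

In this assay the fluorine's place on the aryl ring matters: 4-fluorophenyl in place of 3-fluorophenyl on the amide-type nitrogen gives a 2.9-fold higher number from compound 2 to compound 3 (0.47 log units; beyond the scatter) and keeps every atom of the compound. With 4-fluorophenyl held fixed, carbamoyl in place of hydrogen on an aromatic carbon gives an 8.3-fold lower number from compound 1 to compound 3 (0.92 log units; beyond the scatter) and so isolates the carboxamide as a change that counts on its own, which the pair of compound 1 and compound 2 could not do. Nothing at hand explains either step.

The compounds shown cannot tell whether the carbamoyl step would be the same size with 3-fluorophenyl on that nitrogen. They also leave open how a plain phenyl, a chlorophenyl or a methoxyphenyl would behave there, and whether a nitrile or a carboxylic acid could stand in for the carbamoyl group.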